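Replacing 4-bromophenyl with naphthalen-1-yl on the shared core

The source may hold more compounds than are shown below. What is called first, only, known or untested is meant among the compounds shown, and "the series" means these compounds.

In a functional assay (aorta) with Oryctolagus cuniculus as the target (a lower number here means tighter binding, a higher number weaker binding), three compounds built on one shared core have been measured so far. Compound 1 `CC(=O)c1ccc(OCCCN2CCC(C(c3ccc(F)cc3)c3ccc(F)cc3)CC2)cc1` gives 2.51 nM, compound 2 `Fc1ccc(C(c2ccc(F)cc2)C2CCN(CCCOc3ccc(Cl)cc3)CC2)cc1` gives 2 nM, and compound 3 `Fc1ccc(C(c2ccc(F)cc2)C2CCN(CCCOc3ccc(Br)cc3)CC2)cc1` gives 1.59 nM. Compound 3 therefore cannot be told apart from the other two: the gaps are a 1.3-fold lower number from compound 2 to compound 3 (0.10 log units; within the scatter) and a 1.6-fold lower number from compound 1 to compound 3 (0.20 log units; within the scatter), and both lie within the usual scatter of repeated measurements.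

The next structure, compound 4 `Fc1ccc(C(c2ccc(F)cc2)C2CCN(CCCOc3cccc4ccccc34)CC2)cc1`, brings a larger exchange: naphthalen-1-yl in place of 4-bromophenyl on an oxygen on a saturated carbon. Put simply, naphthalen-1-yl stands in place of 4-bromophenyl on an oxygen on a saturated carbon.

The nearest evidence comes from the exchanges of a single group on an aromatic carbon, namely a 1.3-fold lower number from compound 1 to compound 2 (0.10 log units; within the scatter), together with the two gaps above. All three are small, yet none replaces a whole aromatic unit, so the support is only indirect. No step beyond the scatter is therefore expected in this assay, in either direction, although a wider margin is sensible. The expected step is a 1.3-fold higher number from compound 3 to compound 4 (0.10 log units; within the scatter). For compound 4 the estimated value is 2 nM, with an expected range from 0.7 nM to 6 nM.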

Compound 4, dissociation constant: 5.01 nM
Compound 4: the middle estimate sits 2.5-fold (0.40 log units) below what was measured; the range from low to high includes it.
By their numbers in this assay, from the lowest: compounds 3, 2, 1 and 4 (each within the scatter of the next, the first and the last beyond it).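

In this assay, the earlier exchanges swapped a single group on an aromatic carbon and none left the scatter, whereas exchanging the whole aromatic unit on the oxygen does so in two cases: a 3.2-fold higher number from compound 3 to compound 4 (0.50 log units; beyond the scatter) and a 2.5-fold higher number from compound 2 to compound 4 (0.40 log units; beyond the scatter) both lie beyond the scatter, though both are modest. This position therefore does respond when 4-bromophenyl or 4-chlorophenyl gives way to naphthalen-1-yl, with two six-membered aromatic rings of carbon only in place of one, but compound 1 goes against a clean split between the two kinds of unit, as a 2.0-fold higher number from compound 1 to compound 4 (0.30 log units; within the scatter) stays within the scatter. Nothing measured here accounts for this shift.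

The compounds shown leave open whether the step belongs to the second ring itself or to the way it is attached, a question that naphthalen-2-yl or a plain phenyl group would help to settle. As far as these compounds go, it also remains open how an amine or a carboxylic acid on the aromatic unit, or a longer chain leading to the oxygen, would read in this assay.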